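A Chloro Substituent on the Diethylamino Ring of Compound 1

This account rests on a few compounds, and the source may have more. Where it says the series, first, only, none or still open, it means among the compounds named here.

Compound 1 `CCN(CC)c1ccc(NC(=S)N2CCC(C(O)(c3ccccc3)c3ccccc3)CC2)cc1` gives 72 nM in a functional assay for antagonist activity at Neuropeptide Y receptor type 2 (Homo sapiens) (on this read-out higher numbers stand for weaker inhibition and lower numbers for stronger inhibition), the lowest of the two numbers measured. Going by the values given here, compound 2 `CN(C)C(=O)c1ccc(NC(=S)N2CCC(C(O)(c3ccccc3)c3ccccc3)CC2)cc1` gives 301 nM in this assay, and the step of a 4.2-fold higher number from compound 1 to compound 2 (0.62 log units; beyond the scatter) is the only measured step. Compound 3 `CCN(CC)c1ccc(NC(=S)N2CCC(C(O)(c3ccccc3)c3ccccc3)CC2)cc1Cl` differs from compound 1 by chloro in place of hydrogen on an aromatic carbon. Among the compounds with values here, the measured step from compound 1 to compound 2 concerns a different change, so no measured step bears directly on this one, and no step beyond the scatter is expected in this assay. Compound 3 is therefore estimated at 80 nM, within a range from 30 nM to 250 nM, an expected step of a 1.1-fold higher number from compound 1 to compound 3 (0.05 log units; within the scatter).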

Compound 3, half-maximal inhibitory concentration: 85 nM
The estimate for compound 3 lay 1.1-fold (0.03 log units) below the measured number; the measured number falls inside the stated range.
By their numbers in this assay, from the lowest: compounds 1 and 3 (each within the scatter of the next); then compound 2.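

Chloro in place of hydrogen on the aromatic carbon ortho to the diethylamino group gives a 1.2-fold higher number from compound 1 to compound 3 (0.07 log units; within the scatter) in this assay. Going by these compounds alone, this position therefore accepts a chlorine atom with no step that stands out from the scatter, which the earlier change at the diethylamino group itself could not show. No supporting data are available to account for this result. On these data alone, whether methoxy or an amine at this position would behave the same remains open, as does the effect of chloro alongside the dimethylcarbamoyl group of compound 2.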